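The source may report more compounds than this note shows. Statements on the series, on what has been measured and on what is new or still open speak of the compounds shown alone.

Measured in a functional assay on MCF7 cells (Homo sapiens) for cytotoxicity, read by MTT assay, with a stated time of 72 h; a higher number here means a weaker inhibitor, a lower number a stronger inhibitor:
- Compound 1 `NCCCNc1c(C(=O)NCc2ccc(F)cc2)nc(Br)c2cccnc12`: 6000 nM
- Compound 2 `O=C(NCCCNc1c(C(=O)NCc2ccc(F)cc2)nc(Br)c2cccnc12)c1ccccc1`: 2000 nM
- Compound 3 `CS(=O)(=O)NCCCN(c1nc(C(=O)NCc2ccc(F)cc2)c(O)c2ncccc12)S(C)(=O)=O`: > 20000 nM, a limit and not a number

Compound 3 stands at the limit of > 20000 nM in this assay, at which 1 of the 3 values shown sits. Its place in this assay is therefore known only as a limit.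

Compound 4 `CS(=O)(=O)NCCCCCCN(c1nc(C(=O)NCc2ccc(F)cc2)c(O)c2ncccc12)S(C)(=O)=O` differs from compound 3 in one place: 3-(methanesulfonamido)propyl in place of methanesulfonamido on a saturated chain carbon, three bonds along the chain from a sulfonamide nitrogen. In words, this is 3-(methanesulfonamido)propyl in place of methanesulfonamido on a saturated chain carbon, three bonds along the chain from a sulfonamide nitrogen. Cut one bond further out, the same change reads 3-(methanesulfonamido)propyl to 6-(methanesulfonamido)hexyl.

For the measured compounds named here, only one measured step offers any guide: a 3.0-fold lower number from compound 1 to compound 2 (0.48 log units; beyond the scatter), with benzoyl in place of hydrogen on an amine nitrogen. That step is modest, and it involves a different change on a differently substituted core, so it bears only loosely on this case. A similarly modest move toward a lower number is therefore expected, though no change beyond the scatter is just as plausible, and a second limit reading is quite likely. The estimated step is an at least 1.3-fold lower number from compound 3 to compound 4 (0.12 log units; that floor lies within the scatter). For compound 4 the expected value is 15000 nM, with an estimated range from 6000 nM to 40000 nM.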

Compound 4, half-maximal inhibitory concentration: 7000 nM
Beside the measured number, compound 4's estimate is 2.1-fold (0.33 log units) above it; the range from low to high includes it.
By their numbers in this assay, from the lowest: compound 2; then compounds 1 and 4 (each within the scatter of the next). At a limit, above all of these: compound 3.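

In this assay, 6-(methanesulfonamido)hexyl in place of 3-(methanesulfonamido)propyl gives an at least 2.8-fold lower number from compound 3 to compound 4 (0.45 log units; beyond the scatter). For the compounds shown here, the earlier step changed what sits on the end of a chain, whereas here the methanesulfonamido end and the shared core stay the same and only the length of the saturated chain differs, so this is the first sign that chain length alone can shift the number in this assay. The true size of the step remains unknown, and it can be stated only as a floor because compound 3 carries a limit and not a number: the limit of > 20000 nM in this assay, at which 1 of the 4 values shown sits.

From the compounds shown here alone, two chain lengths cannot show a trend, so it remains open whether a still longer chain, such as an octyl linker ending in methanesulfonamido, would lower the number further, or whether the intermediate 4-(methanesulfonamido)butyl chain would already do as well as the hexyl one. Also open, going by these compounds, is how much the methanesulfonamido end itself contributes, which a carboxylic acid or a free amine at the end of the hexyl chain on this same core would help to settle.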